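Swapping Iodo for Ethyl: A Small Step Expected

A few compounds are considered here, and "the series" means these few. Any claim that something is new, unique, unknown or untested is made for them only; others in the source may bear on it.

In a functional assay on M21 cells (Homo sapiens) for antiproliferative activity, read by sulforhodamine B assay, with a stated time of 48 h (a higher number here means a weaker inhibitor, a lower number a stronger inhibitor), compound 3 (`O=C1NCCN1c1ccc(S(=O)(=O)Nc2ccc(I)cc2)cc1`) gives 260 nM as its reading. Compound 1 (`CCCCc1ccc(NS(=O)(=O)c2ccc(N3CCNC3=O)cc2)cc1`) gives 450 nM on the same read-out, and compound 2 (`Cc1ccc(NS(=O)(=O)c2ccc(N3CCNC3=O)cc2)cc1C`) gives 94 nM there. Compound 3 therefore holds the middle of the three numbers, within the scatter of compound 1 and beyond the scatter above compound 2.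

The next compound is compound 4 (`CCc1ccc(NS(=O)(=O)c2ccc(N3CCNC3=O)cc2)cc1`), which carries ethyl in place of iodo on an aromatic carbon, para to a large group (ethyl in place of iodo on an aromatic carbon). The closest measured change, iodo in place of butyl on an aromatic carbon, gives a 1.7-fold lower number from compound 1 to compound 3 (0.24 log units; within the scatter) and so shows no clear shift. The other measured change, 4-iodophenyl in place of 3,4-dimethylphenyl on a sulfonamide nitrogen, gives a 2.8-fold higher number from compound 2 to compound 3 (0.44 log units; beyond the scatter) as a modest step, but it bears less directly on a single ethyl group.

No step beyond the scatter is therefore expected, and the expected change is a 1.0-fold lower number from compound 3 to compound 4 (0.02 log units; within the scatter) in this assay terms. The estimate for compound 4 is 250 nM as the expected value, within an expected range of 110 nM to 550 nM for such a measurement.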

Compound 4, half-maximal inhibitory concentration: 480 nM
Estimate against measurement, compound 4: 1.9-fold (0.28 log units) below; measured number inside the range.
By their numbers in this assay, from the lowest: compound 2; then compounds 3, 1 and 4 (each within the scatter of the next).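

In this assay, putting ethyl in place of iodo on this aromatic carbon, para to a large group, gives a 1.8-fold higher number from compound 3 to compound 4 (0.27 log units; within the scatter), and shortening butyl to ethyl at the same place gives a 1.1-fold higher number from compound 1 to compound 4 (0.03 log units; within the scatter), so this read-out does not separate iodo, ethyl and butyl here. Replacing the 3,4-dimethylphenyl group on the sulfonamide nitrogen with 4-ethylphenyl gives a 5.1-fold higher number from compound 2 to compound 4 (0.71 log units; beyond the scatter), so both steps beyond the scatter from the 4-substituted compounds shown here start from the 3,4-dimethylphenyl group. No supporting data bear on why the readings fall this way.

As far as these compounds go, whether an amine or a carboxylic acid at this carbon would stay within the same band remains open. So does whether a methyl group alone, on either carbon of the 3,4-dimethylphenyl group, would give the lower number of compound 2.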